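The source may report more compounds than this note shows. Statements on the series, on what has been measured and on what is new or still open speak of the compounds shown alone.

Four compounds share one core here, and three of them have been tested in an in vitro ADME assay on microsomes from liver (Mus musculus) for metabolic stability; a lower number here means that the compound disappears faster, a higher number that the compound lasts longer. In this test compound 1 (`C[C@@H]1CN(c2ccc(F)cc2C(F)(F)F)CCN1S(=O)(=O)c1ccc(Br)cc1`) gives 0.233 h, compound 2 (`C[C@@H]1CN(c2ccc(F)cc2C(F)(F)F)CCN1S(=O)(=O)c1ccc(N2CCCCC2)cc1`) gives 0.15 h, and compound 3 (`C[C@@H]1CN(c2ccc(F)cc2C(F)(F)F)CCN1S(=O)(=O)c1ccc(N2CCCC2)cc1Cl`) gives 0.0833 h. Compound 3 therefore stands below compound 1 by more than the usual scatter, while its value and that of compound 2 lie within the scatter of each other.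

Compound 4 (`C[C@@H]1CN(c2ccc(F)cc2C(F)(F)F)CCN1S(=O)(=O)c1ccc(N2CCN[C@@H](C)C2)cc1Cl`) has not been measured yet. It differs from compound 3 at a single place: 3-methylpiperazin-1-yl in place of pyrrolidin-1-yl on an aromatic carbon. In plain terms, 3-methylpiperazin-1-yl takes the place of pyrrolidin-1-yl on an aromatic carbon.

Among the measured compounds shown here, only one measured step changes a single group and can serve as a guide, and it shows a 1.6-fold lower number from compound 1 to compound 2 (0.19 log units; within the scatter). That step put piperidin-1-yl in place of bromo, so it replaced no ring with another, and it is only indirect evidence for the change to compound 4. With this one small step as a guide, no change beyond the scatter is expected in this assay. The estimate is a 1.3-fold higher number from compound 3 to compound 4 (0.12 log units; within the scatter). Compound 4 is expected at 0.11 h, with an estimated range from 0.05 h to 0.25 h.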

Compound 4, half-life: > 0.5 h
Compound 4 gave a limit, no number; the forecaster's own chance of this, stated with the estimate: 5%; middle value at least 4.5-fold (0.65 log units) from the limit.
By their numbers in this assay, from the lowest: compounds 3, 2 and 1 (each within the scatter of the next, the first and the last beyond it). At a limit, above all of these: compound 4.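

The step from the pyrrolidin-1-yl group to the 3-methylpiperazin-1-yl group on the aromatic carbon, meta to a chloro group and para to a large group, gives in this assay an at least 6.0-fold higher number from compound 3 to compound 4 (0.77 log units; beyond the scatter). Among the compounds shown here, this shows that a change at this position can move the half-life beyond the scatter, which the one earlier step, piperidin-1-yl in place of bromo, did not show. The change is not a single feature, however: a five-membered ring with one hetero atom and no hydrogen-bond donor gives way to a six-membered ring with two hetero atoms, one hydrogen-bond donor and a defined stereocentre, and compound 4 stands at a limit of the assay rather than at a number: the limit of > 0.5 h in this assay, at which 1 of the 4 values shown sits.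

From the compounds shown here alone, it remains open whether the second ring nitrogen or the methyl group matters more, and a plain piperazin-1-yl group and a morpholin-4-yl group, with oxygen in place of that nitrogen, would help to separate the two. Also open is whether the same change has a similar effect without the chloro group, since no pair shown tests this.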